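Swapping a Pyridine Amide for a Chloroacetamide

A few compounds are considered here, and "the series" means these few. Any claim that something is new, unique, unknown or untested is made for them only; others in the source may bear on it.

Compound 1 `Cc1nc(C)c(CN2CCN(C(=O)c3cccnc3)CC2)nc1C` and compound 2 `COc1ccc(OC)c(/C=C/C(=O)N2CCN(Cc3nc(C)c(C)nc3C)CC2)c1` share a core and differ only in what is attached to the carbonyl. In a functional assay on ECV-304 cells (Homo sapiens), with stated times of 30 min and 6 h (on this read-out lower numbers stand for an effect already at smaller amounts and higher numbers for an effect only at larger amounts of compound), compound 1 gives 220000 nM, and compound 2 gives 376000 nM. Compound 1 shows the lowest of the two numbers, but its gap to compound 2 lies within the scatter, so the two cannot be told apart. Compound 3 `Cc1nc(C)c(CN2CCN(C(=O)CCl)CC2)nc1C` has not yet been measured in this assay. It differs from compound 1 in one place: chloromethyl in place of pyridin-3-yl on a carbonyl carbon. Going by the values given here, no measured pair shows this particular swap, so its size is unknown. A step of no more than the scatter is expected, a 1.1-fold higher number from compound 1 to compound 3 (0.06 log units; within the scatter), because compound 1 at 220000 nM and compound 2 at 376000 nM sit close together despite carrying very different groups on that carbonyl. Compound 3 is therefore estimated at 250000 nM, with a range from 60000 nM to 1000000 nM.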

Compound 3, half-maximal effective concentration: 148000 nM
Compound 3: the middle estimate sits 1.7-fold (0.23 log units) above what was measured; the range from low to high includes it.
By their numbers in this assay, from the lowest: compounds 3, 1 and 2 (each within the scatter of the next, the first and the last beyond it).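

Chloromethyl in place of pyridin-3-yl on a carbonyl carbon gives a direct comparison at this position, and in this assay it produces a 1.5-fold lower number from compound 1 to compound 3 (0.17 log units; within the scatter). The aromatic ring, with its hetero atom and hydrogen-bond acceptor, can therefore be exchanged for a group with no ring and only 2 heavy atoms without a difference that can be told from the scatter, so the ring is not required to keep this read-out at its present level. Nothing available explains why these two compounds read alike.

Going by these compounds, it remains open whether a methyl group, which would show what the chlorine contributes, would also stay within the scatter. An amine or a carboxylic acid on the same carbonyl could show whether this position can move the number beyond the scatter at all.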